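From a Methylcarbamoyl Amide to a Benzothiazole

This account rests on a few compounds, and the source may have more. Where it says the series, first, only, none or still open, it means among the compounds named here.

Compound 1 `O=C(c1ccc(NCc2cncn2Cc2ccc(-c3ccccc3)cc2)cc1-c1ccccc1)N1CCCCC1` gives in a toxicity assay on NIH3T3 cells (Mus musculus) for cytotoxicity, read by resazurin assay (a lower number here means that less compound is needed, a higher number that more compound is needed for the effect), only a limit of the assay, > 1000 nM.
Compound 2 `CC(=O)c1ccc(NCc2cncn2Cc2ccc(-c3ccccc3)cc2)cc1-c1ccccc1` gives in this assay only a limit of the assay, > 10000 nM.
Compound 3 `CNC(=O)c1ccc(NCc2cncn2Cc2ccc(-c3ccccc3)cc2)cc1-c1ccccc1` gives in this assay only a limit of the assay, > 1000 nM.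

Compound 3 therefore stands at a limit, as do the other two values shown. Compound 4 `c1ccc(-c2ccc(Cn3cncc3CNc3ccc(-c4nc5ccccc5s4)c(-c4ccccc4)c3)cc2)cc1` differs from it by 1,3-benzothiazol-2-yl in place of methylcarbamoyl on an aromatic carbon. The steps among the measured compounds, a step that the two limits leave unreadable from compound 1 to compound 2, a step that the two limits leave unreadable from compound 1 to compound 3 and a step that the two limits leave unreadable from compound 2 to compound 3, cannot be read, because the limit of > 1000 nM in this assay, at which 2 of the 3 values shown sit, and the limit of > 10000 nM in this assay, at which 1 of the 3 values shown sits, hide their size. Among the measured compounds shown here, no measured step offers a readable size for this change, so no step beyond the scatter is expected; the expected step is a step that the limit leaves unreadable from compound 3 to compound 4. Compound 4 is expected to give about 5000 nM in this assay, most likely between 1000 nM and 30000 nM.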

Compound 4, half-maximal effective concentration: > 1000 nM
Compound 4 was reported as a limit; the forecaster's own chance of this, stated with the estimate: 60%; the middle value is on the limit's open side.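

Compound 4 gives only a limit of the assay, so its steps from compound 1, compound 2 and compound 3 cannot be read: the limit of > 1000 nM in this assay, at which 3 of the 4 values shown sit, and (the limit of > 10000 nM in this assay, at which 1 of the 4 values shown sits). The compounds shown leave open how much of compound 1, compound 2, compound 3 or compound 4 is needed for the effect in this assay.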